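Acyl sulfonamide series: swapping the sulfonyl substituent

The source may hold more compounds than are shown below. What is called first, only, known or untested is meant among the compounds shown, and "the series" means these compounds.

Of the compounds shown here, three of the shared core have been measured in an ADME assay on microsomes from liver (Homo sapiens) for metabolic stability, with a stated time of 10 min; a higher number here means that more of the compound is left, a lower number that less of the compound is left. Compound 1 `O=C(NS(=O)(=O)CCNC(=O)C1CC1)c1ccc(Nc2nc(NC3(c4ccc(Cl)cc4)CC3)nc(OCC(F)(F)F)n2)cc1` gives 90%. Compound 2 `CC(C)(C)CNCCS(=O)(=O)NC(=O)c1ccc(Nc2nc(NC3(c4ccc(Cl)cc4)CC3)nc(OCC(F)(F)F)n2)cc1` gives 89%. Compound 3 `COC(=O)NCCS(=O)(=O)NC(=O)c1ccc(Nc2nc(NC3(c4ccc(Cl)cc4)CC3)nc(OCC(F)(F)F)n2)cc1` gives 90%. The step of no change at the digits printed from compound 1 to compound 3 (within the scatter) and the step of a number 1 percentage points higher from compound 2 to compound 3 (within the scatter) both lie within the scatter, as does a number 1 percentage points lower from compound 1 to compound 2 (within the scatter). Compound 3 therefore stands level with compound 1, the two together at the top of the three numbers, with compound 2 nearest below and still within the scatter.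

Compound 4 `Cc1ccccc1S(=O)(=O)NC(=O)c1ccc(Nc2nc(NC3(c4ccc(Cl)cc4)CC3)nc(OCC(F)(F)F)n2)cc1` is not yet measured. The change from compound 3 is 2-methylphenyl in place of 2-((methoxycarbonyl)amino)ethyl on a sulfonyl sulfur. None of the three measured steps touches the sulfonyl sulfur; all three vary only the group on the amine nitrogen further out, and each stayed within the scatter. They give no direct guidance on the present change, and the only indication from the measured compounds is that this series has so far been insensitive to variation at the end of the sulfonyl chain. Compound 4 is therefore expected to stay near the present level, with the step of a number 5 percentage points lower from compound 3 to compound 4 (within the scatter) estimated to remain within the scatter. The estimate for compound 4 is 85%, with a range from 70% to 97%.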

Compound 4, percent of the compound remaining: 100%
For compound 4 the middle estimate is 15 percentage points below the measured one; measured number outside the range, above it.
By their numbers in this assay, from the lowest: compounds 2, 1, 3 and 4 (each within the scatter of the next, the first and the last beyond it).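

The 2-methylphenyl group is the only change among the compounds shown that reaches the sulfonyl sulfur itself, and in this assay it gives a number 10 percentage points higher from compound 3 to compound 4 (within the scatter) and a number 10 percentage points higher from compound 1 to compound 4 (within the scatter) while also replacing chains with a ring. The position therefore tolerates a direct exchange of 2-((methoxycarbonyl)amino)ethyl, with its hydrogen-bond donor and acceptors, for a six-membered aromatic ring of carbon only that has neither, without any loss of the level seen so far in this read-out. Among these compounds, the one step beyond the scatter is a number 11 percentage points higher from compound 2 to compound 4 (beyond the scatter) and it is modest, so the aromatic group separates clearly only from the 2-(neopentylamino)ethyl chain, and no data at hand explain the result.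

As far as these compounds go, whether the methyl group on the ring matters stays open, and an unsubstituted phenyl, a pyridine ring or a simple methyl on the sulfonyl sulfur would be needed to separate the role of the ring from that of its substituent. With compound 4 at 100% in this assay the read-out also leaves no room to tell apart any group that holds up as well or better.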